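Cinnamate ester variation on a shared quinolinone core

The source may report more compounds than this note shows. Statements on the series, on what has been measured and on what is new or still open speak of the compounds shown alone.

Measured compounds:
Compound 1, `O=C(CCC1CCCCC1)OCCc1c(-c2ccccc2Cl)c2cc(Cl)ccc2[nH]c1=O`: 160000 nM
Compound 2, `O=C(OCCc1c(-c2ccccc2Cl)c2cc(Cl)ccc2[nH]c1=O)c1ccccc1`: 43000 nM

Of the two numbers in an ADME assay on HepG2 2.2.15 cells (Homo sapiens) for cytotoxicity (a lower number here means that less compound is tolerated, a higher number that more compound is tolerated), compound 2 stands lowest, and the gap to compound 1 is beyond the scatter. Among the measured compounds shown here, the single step in hand is a 3.7-fold lower number from compound 1 to compound 2 (0.57 log units; beyond the scatter). Compound 3, `O=C(/C=C/c1ccc(C(F)(F)F)cc1)OCCc1c(-c2ccccc2Cl)c2cc(Cl)ccc2[nH]c1=O`, has not yet been measured. It differs from compound 2 in one place: 2-(4-(trifluoromethyl)phenyl)ethenyl in place of phenyl on a carbonyl carbon. For the measured compounds named here, the one measured step bears on this only loosely, since it exchanged a saturated side chain for phenyl, whereas here the aryl side is enlarged further. Compound 3 is therefore expected to give a number close to that of compound 2 or somewhat lower, a step of a 1.4-fold lower number from compound 2 to compound 3 (0.16 log units; within the scatter) in this assay . The estimate for compound 3 is 30000 nM, with a range from 10000 nM to 90000 nM.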

Compound 3, half-maximal cytotoxic concentration: > 1400000 nM
Compound 3 gave a limit, no number; the forecaster's own chance of this, stated with the estimate: 10%; middle value at least 46-fold (1.66 log units) from the limit.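

Compound 3 gives a limit and not a number in this assay: the limit of > 1400000 nM in this assay, at which 1 of the 3 values shown sits. Even with only a limit in hand, the step from phenyl to 2-(4-(trifluoromethyl)phenyl)ethenyl on this carbonyl carbon is large, with an at least 32-fold higher number from compound 2 to compound 3 (1.51 log units; beyond the scatter), and the same group also stands clear of 2-cyclohexylethyl, with an at least 8.7-fold higher number from compound 1 to compound 3 (0.94 log units; beyond the scatter). The earlier pair had shown only a 3.7-fold lower number from compound 1 to compound 2 (0.57 log units; beyond the scatter), so this position can shift the tolerated concentration much further than that step suggested, and in the opposite direction.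

The compounds shown leave open whether the double bond or the trifluoromethyl group carries the step, which a plain 2-phenylethenyl group would help to separate. From the compounds shown here alone, how an amine or a carboxylic acid on the aromatic ring of this side chain would read in this assay also stays open.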